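The source may hold more compounds than are shown below. What is called first, only, known or untested is meant among the compounds shown, and "the series" means these compounds.

Measured compounds:
Compound 1 `O=C(N[C@H]1CC[C@H](C(=O)O)CC1)[C@H](C1CCCCC1)n1c(-c2ccc(Cl)nc2)nc2cc(F)c(F)cc21`: in a functional assay for agonist activity at Bile acid receptor (Homo sapiens), read by a luciferase reporter (on this read-out higher numbers stand for an effect only at larger amounts of compound and lower numbers for an effect already at smaller amounts), compound 1 gives 9700 nM.
Compound 2 `O=C(O)c1ccccc1NC(=O)C(C1CCCCC1)n1c(-c2ccc(Cl)cc2)nc2cc(F)c(F)cc21`: in this assay compound 2 gives only a limit, > 40000 nM.
Compound 3 `O=C(O)c1cccc(NC(=O)C(C2CCCCC2)n2c(-c3ccc(Cl)cc3)nc3cc(F)c(F)cc32)c1`: in this assay compound 3 gives 10700 nM.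

Compound 3 has the highest of the two numbers; compound 1 sits within the scatter of it, and compound 2 is a limit only (the limit of > 40000 nM in this assay, at which 1 of the 3 values shown sits). For the measured compounds named here, the one measured step, an at least 3.7-fold lower number from compound 2 to compound 3 (0.57 log units; beyond the scatter), moves the carboxyphenyl substituent on the amide nitrogen and is at least modest. Compound 4 `Cc1nc(NC(=O)C(C2CCCCC2)n2c(-c3ccc(Cl)cc3)nc3cc(F)c(F)cc32)sc1C(=O)O` differs from compound 3 by 5-carboxy-4-methyl-1,3-thiazol-2-yl in place of 3-carboxyphenyl on an amide-type nitrogen. Going by the values given here, no measured step exchanges the aromatic ring itself, so the step is expected to stay within the scatter, a 1.1-fold higher number from compound 3 to compound 4 (0.05 log units; within the scatter). For compound 4 a value of 12000 nM is estimated, between 4000 nM and 40000 nM.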

Compound 4, half-maximal effective concentration: 10400 nM
Estimate against measurement, compound 4: 1.2-fold (0.06 log units) above; measured number inside the range.
By their numbers in this assay, from the lowest: compounds 1, 4 and 3 (each within the scatter of the next). At a limit, above all of these: compound 2.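

On the amide-type nitrogen, a five-membered aromatic ring with 2 hetero atoms can replace the six-membered carbon ring: the exchange gives a 1.0-fold lower number from compound 3 to compound 4 (0.01 log units; within the scatter), so the ring type itself does not move the read-out beyond the scatter. The step of an at least 3.8-fold lower number from compound 2 to compound 4 (0.58 log units; beyond the scatter) places the 2-carboxyphenyl compound apart from this second ring type as well, though only against a limit: the limit of > 40000 nM in this assay, at which 1 of the 4 values shown sits.

Open, going by these compounds, is how a methyl ester or a primary amide in place of the carboxylic acid would read on either ring. Also open, on these data alone, is what the methyl group of 5-carboxy-4-methyl-1,3-thiazol-2-yl contributes on its own.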